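Substituents on the Phenoxy Ring in a Pancreatic Cell Assay

The compounds below may be only part of what the source reports. "The series", "measured", "known", "first", "only" and "open" are said of these compounds alone.

Compound 1 `CNC(=O)c1cccc(Cn2nc(C)c(NC(=O)c3ccc(COc4ccccc4)cc3)c2C)c1` has been measured in a functional assay on MIA PaCa-2 cells (Homo sapiens) for antiproliferative activity, read by MTT assay, with a stated time of 72 h (a higher number here means that more compound is needed for the effect, a lower number that less compound is needed), where compound 1 gives 6200 nM. Among the three compounds measured so far, compound 1 stands second highest: compound 2 `CNC(=O)c1cccc(Cn2nc(C)c(NC(=O)c3ccc(COc4ccccc4OC)cc3)c2C)c1` gives 8500 nM, and compound 3 `CNC(=O)c1cccc(Cn2nc(C)c(NC(=O)c3ccc(COc4ccc(Cl)cc4)cc3)c2C)c1` gives 4200 nM. Both neighbours lie within the scatter of compound 1, with a 1.4-fold higher number from compound 1 to compound 2 (0.14 log units; within the scatter) and a 1.5-fold lower number from compound 1 to compound 3 (0.17 log units; within the scatter); only the gap between the two substituted compounds, a 2.0-fold lower number from compound 2 to compound 3 (0.31 log units; beyond the scatter), reaches beyond it, and modestly so.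

Compound 4 `CNC(=O)c1cccc(Cn2nc(C)c(NC(=O)c3ccc(COc4ccc(C(F)(F)F)cc4C)cc3)c2C)c1` has not yet been measured. It differs from compound 1 in one place: 2-methyl-4-(trifluoromethyl)phenyl in place of phenyl on an oxygen on a saturated carbon. The two measured steps that bear on this change each put a single group onto the same phenoxy ring, and each stayed within the scatter. Compound 4 carries two groups at once, a methyl and a trifluoromethyl, on that ring; the chloro of compound 3 is the closer precedent, so a small move towards a lower number, or none beyond the scatter, is expected in this assay. Compound 4 is therefore estimated at 4500 nM, within 2000 nM to 10000 nM, which corresponds to an expected step of a 1.4-fold lower number from compound 1 to compound 4 (0.14 log units; within the scatter).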

Compound 4, half-maximal effective concentration: 620 nM
Estimate against measurement, compound 4: 7.3-fold (0.86 log units) above, outside the stated range (below it).
By their numbers in this assay, from the lowest: compound 4; then compounds 3, 1 and 2 (each within the scatter of the next, the first and the last beyond it).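

In this assay, for the compounds shown here, the phenoxy ring proves to be a place where the number can move far: the single methoxy and chloro groups stayed within the scatter of compound 1, whereas 2-methyl-4-(trifluoromethyl)phenyl gives a 10-fold lower number from compound 1 to compound 4 (1.00 log units; beyond the scatter) in a single change. The new group also stands clear of both singly substituted rings, with a 6.8-fold lower number from compound 3 to compound 4 (0.83 log units; beyond the scatter) and with a 14-fold lower number from compound 2 to compound 4 (1.14 log units; beyond the scatter) as the two further steps, which leaves compound 4 with the lowest number of the four, beyond the scatter of each of the others. No measurement shown here speaks to why this change has an effect of this size.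

Because the methyl and the trifluoromethyl enter together, the compounds shown leave open whether one of them carries the step or whether it takes both, a question that 2-methylphenyl and 4-(trifluoromethyl)phenyl on the same oxygen would address. They also leave open how far the trend extends on this ring, for instance to a nitrile, a carboxylic acid or an amine in place of the trifluoromethyl.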